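The compounds below may be only part of what the source reports. "The series", "measured", "known", "first", "only" and "open" are said of these compounds alone.

Measured compounds:
compound 1 `CCn1c(-c2ccccc2)nc2c(NC3CCCCC3)ncnc21` — 10 nM
compound 2 `COc1ccc(-c2nc3c(NC4CCCC4)ncnc3n2C)cc1` — 75 nM
compound 3 `Cn1c(-c2ccccc2)nc2c(NC3CCCCC3)ncnc21` — 5.7 nM

All three numbers come from an assay on CHO cells for displacement of a labelled ligand from adenosine receptor A1 (Homo sapiens), read by scintillation counting, with a stated time of 3 h; a lower number here means a stronger inhibitor, a higher number a weaker inhibitor. Compound 1 stands second highest of the three. Its nearest neighbour is compound 3: a 1.8-fold lower number from compound 1 to compound 3 (0.24 log units; within the scatter), so the two cannot be placed in any order. Among the measured compounds shown here, its furthest neighbour is compound 2, whose number in this assay is the highest of the set; compound 2 differs from compound 3 in two places at once, so the two values show only that the pair lies well apart, not which change carries it.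

Compound 4 `CCn1c(-c2ccccc2)nc2c(NC3CCOC3)ncnc21` is the next compound to be measured in this assay. Relative to compound 1 the change is oxolan-3-yl in place of cyclohexyl on a nitrogen on an aromatic ring. For the measured compounds named here, no measured step bears on this change: the only measured single-point step, from compound 1 to compound 3, is on the saturated chain carbon bound to the aromatic nitrogen and is within the scatter, and no measured pair isolates the group on the ring nitrogen. The expectation is therefore weakly founded; it leans toward a higher number, with a wide range. For compound 4 the expected step is a 6.0-fold higher number from compound 1 to compound 4 (0.78 log units; beyond the scatter). Compound 4 is estimated at 60 nM, within 15 nM to 250 nM.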

Compound 4, inhibition constant: 10 nM
For compound 4 the middle estimate is 6.0-fold (0.78 log units) above the measured one; measured number below the stated range.
By their numbers in this assay, from the lowest: compounds 3, 1 and 4 (each within the scatter of the next); then compound 2.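

In this assay, among the compounds shown here, the reading is no change at the digits printed from compound 1 to compound 4 (within the scatter) and this is the first measured step at this position, since the earlier single-point step sat on the saturated chain carbon bound to the aromatic nitrogen. On a nitrogen on an aromatic ring, then, a six-membered ring of carbon only and a five-membered ring with one oxygen, which brings a hydrogen-bond acceptor that cyclohexyl lacks, cannot be told apart in this assay. No measurement shown here offers an explanation for this result.

Ring size and the ring oxygen change together in this single step, so the compounds shown do not say what either change does alone, and oxan-4-yl on the same nitrogen of the core of compound 1 would keep the six-membered ring while carrying the oxygen. Also open, from the compounds shown here alone, is how far this position tolerates other groups, such as an amine in the form of piperidin-4-yl or a carboxylic acid on the ring.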